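Methyl in place of hydrogen: compound 2 to compound 4

A few compounds are considered here, and "the series" means these few. Any claim that something is new, unique, unknown or untested is made for them only; others in the source may bear on it.

Measured compounds:
compound 1 `CNC(=O)c1sc(N2CC3CC2(CNC(=O)c2c[nH]c4ncc(C(F)(F)F)cc24)C3)nc1C(F)(F)F` 63.1 nM
compound 2 `CNC(=O)c1sc(N2CC3CC2(CNC(=O)c2c[nH]c4ncccc24)C3)nc1C(F)(F)F` 25.1 nM
compound 3 `CNc1nc(OCC2CCC2)nc2c1ncn2Cc1c(F)cccc1F` 50.1 nM

In an assay on isolated protein for inhibition of tyrosine-protein kinase Mer (Homo sapiens), read by LC-MS, with stated times of 30 min and 120 min (on this read-out lower numbers stand for stronger inhibition and higher numbers for weaker inhibition), compound 2 gives the lowest of the three numbers. Among the compounds with values here, compound 3 sits within the scatter of it, so no order between those two can be read; compound 1 lies beyond the scatter, and the step of a 2.5-fold lower number from compound 1 to compound 2 (0.40 log units; beyond the scatter) is the only single-point change measured.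

Compound 4 `CNC(=O)c1sc(N2CC3CC2(CNC(=O)c2c[nH]c4ncc(C)cc24)C3)nc1C(F)(F)F` differs from compound 2 by methyl in place of hydrogen on an aromatic carbon. Within the data shown here, the carbon concerned is the one that carries trifluoromethyl in compound 1, so a 2.5-fold lower number from compound 1 to compound 2 (0.40 log units; beyond the scatter) is the only step that bears on this change. That step shows a modest rise in the number when the carbon carries a group rather than hydrogen. Methyl is a different group, and no methyl analogue is measured, so the direction is taken from compound 1 alone and the size is uncertain; a rise no larger than that step, possibly within the scatter, is expected.

For compound 4 in this assay the expected value is 35 nM (range 15 nM to 80 nM), corresponding to an expected step of a 1.4-fold higher number from compound 2 to compound 4 (0.14 log units; within the scatter).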

Compound 4, half-maximal inhibitory concentration: 12.6 nM
Compound 4: the middle estimate sits 2.8-fold (0.44 log units) above what was measured; the measured number lies below the stated range.
By their numbers in this assay, from the lowest: compounds 4, 2, 3 and 1 (each within the scatter of the next, the first and the last beyond it).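

In this assay this aromatic carbon accepts methyl without a change that can be read (a 2.0-fold lower number from compound 2 to compound 4 (0.30 log units; within the scatter)), so hydrogen and methyl cannot be ordered here. Exchanging one group for the other on the same carbon does give a readable difference (a 5.0-fold lower number from compound 1 to compound 4 (0.70 log units; beyond the scatter)), which shows that the higher number of compound 1 belongs to trifluoromethyl and does not extend to every group at this position. Nothing at hand accounts for the difference between methyl and trifluoromethyl here.

As far as these compounds go, whether any group on this carbon can take the number beyond the scatter of compound 2 remains open. Ethyl, a longer chain, chlorine, methoxy or an amine at the same place would show how far the trend from trifluoromethyl to methyl carries, and whether it depends on the kind of group or only its size.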